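Swapping a small isopropyl for a large ring-bearing group

The compounds below may be only part of what the source reports. "The series", "measured", "known", "first", "only" and "open" are said of these compounds alone.

In a functional assay (aorta) for inhibition, with Oryctolagus cuniculus as the target (a higher number here means a weaker inhibitor, a lower number a stronger inhibitor), compound 2 `CCO/C(O)=C1\C(C)=NC(=S)N(C(=O)OC(C)C)C1c1ccccc1C(F)(F)F` gives 50 nM and compound 1 `CCOC(=O)N1C(=S)N=C(C)/C(=C(/O)OCC)C1c1ccccc1C(F)(F)F` gives 41 nM. The measured step of a 1.2-fold higher number from compound 1 to compound 2 (0.09 log units; within the scatter) lies within the scatter, so this small change says little about a much larger one. Compound 3 `CCO/C(O)=C1\C(C)=NC(=S)N(C(=O)OC2CCN(Cc3ccccc3)CC2)C1c1ccccc1C(F)(F)F`, which carries a large nitrogen-containing ring group on the same oxygen, gives 9 nM, a number clearly lower than that of compound 2. The change to compound 4 `CCO/C(O)=C1\C(C)=NC(=S)N(C(=O)O[C@H]2CCN(Cc3ccccc3)C2)C1c1ccccc1C(F)(F)F` is a group of 12 heavy atoms (11 carbon, 1 nitrogen; one five-membered non-aromatic ring with 1 hetero atom, one six-membered aromatic ring of carbon only) in place of a group of 3 heavy atoms (3 carbon; no ring), on an oxygen next to a carbonyl group. Compound 3 at 9 nM is the closest guide, so a clear drop is expected in this assay, an estimated 4.2-fold lower number from compound 2 to compound 4 (0.62 log units; beyond the scatter). For compound 4 the expected value is 12 nM, with an estimated range of 4 nM to 35 nM.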

Compound 4, half-maximal inhibitory concentration: 2 nM
Compound 4: the middle estimate sits 6.0-fold (0.78 log units) above what was measured; measured number below the stated range.
By their numbers in this assay, from the lowest: compound 4; then compound 3; then compounds 1 and 2 (each within the scatter of the next).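

In this assay, the large ring-bearing group on this oxygen next to a carbonyl group brings a large gain, with a 25-fold lower number from compound 2 to compound 4 (1.40 log units; beyond the scatter) and a 21-fold lower number from compound 1 to compound 4 (1.31 log units; beyond the scatter) as its steps. The position therefore takes a group far bigger than isopropyl, and the number falls well beyond the scatter. Numbers stay low for both large groups, compound 3 (9 nM) and compound 4 (2 nM), so this gain is not tied to one exact ring.

Nothing measured here explains the gain. Still open, from the compounds shown here alone, is how the mirror-image form of compound 4 behaves, and whether a simple amine chain or a carboxylic acid at this position would do as well.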